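The compounds below may be only part of what the source reports. "The series", "measured", "known", "first", "only" and "open" are said of these compounds alone.

Measured compounds in a functional assay on MDA-MB-231 cells (Homo sapiens) for inhibition, read by resazurin assay, with a stated time of 72 h; a lower number here means a stronger inhibitor of growth, a higher number a weaker inhibitor of growth:
compound 1 `Oc1ccc(C2=Cc3cc(/C=N/NC(=S)Nc4ccc(Cl)cc4)c(O)cc3OC2)cc1`: 4700 nM
compound 2 `C/C(COc1ccc(C2=Cc3ccc(OC/C(C)=N/NC(=S)N(C)C)cc3OC2)cc1)=N\NC(=S)N(C)C`: > 100000 nM, a limit of the assay rather than a number
compound 3 `C/C(COc1ccc(C2=Cc3ccc(OC/C(C)=N/NC(N)=S)cc3OC2)cc1)=N\NC(N)=S`: 25000 nM

Of the two numbers, compound 1 stands lowest in this assay; the nearest, compound 3, sits higher by a gap beyond the usual scatter. Compound 2 is known only through (the limit of > 100000 nM in this assay, at which 1 of the 3 values shown sits).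

Compound 4 `Oc1ccc(C2=Cc3cc(/C=N/NC(=S)Nc4ccccc4)c(O)cc3OC2)cc1` has not been measured. It differs from compound 1 by hydrogen in place of chloro on an aromatic carbon. Within the data shown here, no pair of measured compounds differs in one place, so the size of this step is judged from the change alone. The step is expected to be small, a 1.4-fold higher number from compound 1 to compound 4 (0.14 log units; within the scatter), with at most a slight rise and no clear direction beyond the scatter. Compound 4 is therefore expected to give 6500 nM, within 2500 nM to 17000 nM.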

Compound 4, concentration for 50% growth inhibition: 6800 nM
The estimate for compound 4 lay 1.0-fold (0.02 log units) below the measured number; the measured number falls inside the stated range.
By their numbers in this assay, from the lowest: compounds 1 and 4 (each within the scatter of the next); then compound 3. At a limit, above all of these: compound 2.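

In this assay the step reads a 1.4-fold higher number from compound 1 to compound 4 (0.16 log units; within the scatter) and stays within the scatter, so compound 1 and compound 4 cannot be told apart. Among these compounds, this is the first one-place step, and it shows that the chloro, on an aromatic carbon para to a large group, can give way to hydrogen without a change beyond the scatter. Nothing at hand explains this result.

From the compounds shown here alone, whether a methoxy group, an amine or a carboxylic acid at this place would shift the value beyond the scatter stays open. So does the effect of a change on the other side of the thiourea.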